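The compounds below may be only part of what the source reports. "The series", "measured", "known", "first", "only" and "open" are said of these compounds alone.

Compound 1, `CCN(CC)CCCCOc1ccc(C(=O)/C=C/c2ccccc2)cc1`, gives 1.74 in a physicochemical assay for lipophilicity, using the shake flask method, measured as octanol-water partition, at pH 7.4; a lower number here means a more polar compound, a higher number a more lipophilic compound.
Compound 2, `CCCN(CCC)CCCCOc1ccc(C(=O)/C=C/c2ccccc2)cc1`, gives 1.95 in this assay.
Compound 3, `CN(C)CCCCCOc1ccc(C(=O)/C=C/c2ccccc2)cc1`, gives 1.73 in this assay.

All three share the same core and differ only in the amine at the end of the chain. Compound 3 is not set apart from the others in this assay: the step of a number 0.01 log units lower from compound 1 to compound 3 (within the scatter) and the step of a number 0.22 log units lower from compound 2 to compound 3 (within the scatter) both stay inside the scatter of repeated measurements, as does the step of a number 0.21 log units higher from compound 1 to compound 2 (within the scatter) between the other two.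

Compound 4, `CCN(CC)CCCCCOc1ccc(C(=O)/C=C/c2ccccc2)cc1`, has not yet been measured. It differs from compound 3 in one place: diethylamino in place of dimethylamino on a saturated chain carbon, five bonds along the chain from an oxygen on an aromatic ring. The closest guide is the step of a number 0.01 log units lower from compound 1 to compound 3 (within the scatter), which runs the same exchange of amines backwards and barely moves; the step of a number 0.21 log units higher from compound 1 to compound 2 (within the scatter), which also adds two carbons to the amine, stays within the scatter as well. The expected step of a number 0.17 log units higher from compound 3 to compound 4 (within the scatter) is therefore small. Compound 4 is estimated at 1.9, with a range from 1.6 to 2.2.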

Compound 4, partition coefficient: 1.84
The estimate for compound 4 lay 0.06 log units above the measured number; the range from low to high includes it.
By their numbers in this assay, from the lowest: compounds 3, 1, 4 and 2 (each within the scatter of the next).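

In this assay, the exchange of dimethylamino for diethylamino, on a saturated chain carbon five bonds along the chain from an oxygen on an aromatic ring, now has a direct reading (a number 0.11 log units higher from compound 3 to compound 4 (within the scatter)), and it does not separate the two compounds. For the compounds shown here, the chain itself can also be read for the first time with the amine kept the same, as (diethylamino)methyl in place of diethylamino (a number 0.10 log units higher from compound 1 to compound 4 (within the scatter)), and this too stays inside the scatter. The exchange of dipropylamino for (diethylamino)methyl (a number 0.11 log units lower from compound 2 to compound 4 (within the scatter)) does the same, so the four compounds cannot be told apart in this assay.

From the compounds shown here alone, it remains open whether a different end group, such as a piperidine ring or a carboxylic acid, or a longer chain, would give a step beyond the scatter. No evidence is available to explain how close these numbers lie.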